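Lengthening the Hexyl Chain on the Aromatic Oxygen

The source may report more compounds than this note shows. Statements on the series, on what has been measured and on what is new or still open speak of the compounds shown alone.

Among the measured compounds shown here, in a functional assay on brain (Rattus norvegicus, strain Wistar) for inhibition (a lower number here means a stronger inhibitor, a higher number a weaker inhibitor), only two compounds have numbers so far. Compound 1 `Cc1[nH]c(=O)n(C)c1-c1ccc(OC(C)C)cc1`, with isopropyl on an oxygen on an aromatic ring, gives 20400 nM. Compound 2 `CCCCCCOc1ccc(-c2c(C)[nH]c(=O)n2C)cc1`, with hexyl in that place, gives 7300 nM, the lower of the two numbers and therefore the stronger inhibitor of the pair.

Compound 3 `CCCCCCCOc1ccc(-c2c(C)[nH]c(=O)n2C)cc1` has yet to be measured in this assay. It departs from compound 2 by methyl in place of hydrogen on a saturated chain carbon, six bonds along the chain from an oxygen on an aromatic ring, so the change is confined to the far end of the chain. For the measured compounds named here, only one measured step bears on this, a 2.8-fold lower number from compound 1 to compound 2 (0.45 log units; beyond the scatter), which is modest but beyond the scatter. That step replaced isopropyl with hexyl, a much larger alteration than the present one, and a single step does not establish a trend. A small further move towards a lower number is therefore expected, probably not beyond the scatter. The expected step is a 1.3-fold lower number from compound 2 to compound 3 (0.10 log units; within the scatter). For compound 3 the estimated value is 5800 nM, with an expected range of 2600 nM to 12500 nM.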

Compound 3, half-maximal inhibitory concentration: 5700 nM
Compound 3: middle estimate off by 1.0-fold (0.01 log units), on the high side; the range from low to high includes it.
By their numbers in this assay, from the lowest: compounds 3 and 2 (each within the scatter of the next); then compound 1.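

In this assay, among the compounds shown here, methyl in place of hydrogen on a saturated chain carbon, six bonds along the chain from an oxygen on an aromatic ring, gives a 1.3-fold lower number from compound 2 to compound 3 (0.11 log units; within the scatter), so compound 2 and compound 3 cannot be told apart at this position, which the single earlier step could not show. Heptyl in place of isopropyl on the same oxygen gives a 3.6-fold lower number from compound 1 to compound 3 (0.55 log units; beyond the scatter), a modest step beyond the scatter, so the separation from the isopropyl compound seen with hexyl also holds with heptyl. No measurement available here accounts for either step.

As far as these compounds go, whether a longer chain such as octyl or decyl would keep the number where compound 2 and compound 3 stand or move it remains open, as does the outcome of ending the chain in an amine or a carboxylic acid. The compounds shown also leave open how a straight propyl or butyl on the oxygen would compare with isopropyl and hexyl, and so where along the chain the separation from compound 1 first appears.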